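A few compounds are considered here, and "the series" means these few. Any claim that something is new, unique, unknown or untested is made for them only; others in the source may bear on it.

Compound 1 `COc1ccc(/C=C/C(=O)c2ccc(OC)c(N)c2)cc1`: 43000 nM
Compound 2 `COc1ccc(C(=O)/C=C/c2ccc(OC)c(OC)c2)cc1N`: 18000 nM

Among these two numbers in a functional assay on B16 cells (Mus musculus) for cytotoxicity, read by MTT assay, with a stated time of 3 days (on this read-out higher numbers stand for weaker inhibition and lower numbers for stronger inhibition), compound 2 stands lowest; its nearest neighbour is compound 1, and the step from compound 1 to compound 2 was a 2.4-fold lower number from compound 1 to compound 2 (0.38 log units; beyond the scatter). Compound 3 `COc1ccc(C(=O)/C=C/c2cc(OC)c(OC)c(OC)c2)cc1N` differs from compound 2 by methoxy in place of hydrogen on an aromatic carbon. Among the measured compounds shown here, the only measured step that bears on this change is the methoxy addition a 2.4-fold lower number from compound 1 to compound 2 (0.38 log units; beyond the scatter), which was modest but beyond the scatter. A step of similar size and the same direction is therefore expected, namely a 1.8-fold lower number from compound 2 to compound 3 (0.26 log units; within the scatter). Compound 3 is accordingly estimated at 10000 nM, with a range from 4000 nM to 30000 nM.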

Compound 3, half-maximal inhibitory concentration: 67000 nM
For compound 3 the middle estimate is 6.7-fold (0.83 log units) below the measured one; the whole stated range lies below it.
By their numbers in this assay, from the lowest: compound 2; then compounds 1 and 3 (each within the scatter of the next).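

In this assay, methoxy in place of hydrogen on this aromatic carbon, ortho to a methoxy group and meta to a large group, gave a 3.7-fold higher number from compound 2 to compound 3 (0.57 log units; beyond the scatter) and so ran opposite to the earlier methoxy step. The same exchange therefore has no single direction across these two steps on this ring. Nothing measured here accounts for the reversal. Going by these compounds, whether a hydroxy group or an amine at this position would also weaken inhibition remains open. So does whether the change belongs to this position alone or to the methoxy groups taken together.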